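The source may report more compounds than this note shows. Statements on the series, on what has been measured and on what is new or still open speak of the compounds shown alone.

Compound 1: `Cc1cc(O)c(C2=NN(c3ccc(S(N)(=O)=O)cc3)C(/C=C/c3ccccc3)C2)cc1Cl` — 7840 nM
Compound 2: `COc1ccc(C2CC(c3cc(Cl)c(C)cc3O)=NN2c2ccc(S(N)(=O)=O)cc2)cc1OC` — 5530 nM

Of the compounds shown here, two have been measured in a functional assay on SNB-19 cells (Homo sapiens) for antiproliferative activity, with a stated time of 48 h; a higher number here means a weaker inhibitor of growth, a lower number a stronger inhibitor of growth. For the measured compounds named here, compound 1 gives 7840 nM and compound 2 gives 5530 nM; the only step between them, a 1.4-fold lower number from compound 1 to compound 2 (0.15 log units; within the scatter), lies within the scatter, so the two numbers cannot be told apart. Compound 2 therefore stands together with compound 1, neither stronger nor weaker on the evidence so far.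

Compound 3 is `COc1ccc(C2CC(c3cc(Cl)c(C)cc3O)=NN2c2ccc(S(N)(=O)=O)cc2)c(OC)c1OC`. It differs from compound 2 by methoxy in place of hydrogen on an aromatic carbon. Going by the values given here, no measured step bears directly on this change: the one step known, from compound 1 to compound 2, swaps a whole group on a saturated ring carbon rather than adding a methoxy to an aromatic ring, and even that step stayed within the scatter. The one thing the data do show is that a sizeable change at this part of the molecule left this assay almost unmoved. The expectation is a small step, if any, in this assay for compound 3, without a clear direction: a 1.2-fold lower number from compound 2 to compound 3 (0.09 log units; within the scatter) is the estimated step, within the scatter. Compound 3 is thus expected to give about 4500 nM, in a range from 1500 nM to 13000 nM.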

Compound 3, concentration for 50% growth inhibition: 4610 nM
For compound 3 the middle estimate is 1.0-fold (0.01 log units) below the measured one, within the range that was stated.
By their numbers in this assay, from the lowest: compounds 3, 2 and 1 (each within the scatter of the next).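

Compounds 2 and 3 give a direct reading of one added methoxy, placed on an aromatic carbon ortho to a large group and ortho to a methoxy group, and in this assay the result is a 1.2-fold lower number from compound 2 to compound 3 (0.08 log units; within the scatter). The wider change, which swaps the whole group on the saturated ring carbon, gives a 1.7-fold lower number from compound 1 to compound 3 (0.23 log units; within the scatter), so neither the single added methoxy nor the replacement of the whole group separates these compounds in this assay. No supporting measurement is available to explain why these numbers stay so close.

The compounds shown leave open whether a group of a different kind on this aromatic ring, such as an amine or a carboxylic acid, would give a step beyond the scatter. They also leave open what a change elsewhere in the shared core would do, for example a longer chain in place of the methyl group, since all three compounds keep that part the same.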